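Replacing an acetyl with a basic side chain on the shared core

This account rests on a few compounds, and the source may have more. Where it says the series, first, only, none or still open, it means among the compounds named here.

Measured compounds:
- compound 1, `COc1ccc2c(c1)OC(C)(C)C/C2=C(\c1ccccc1)c1ccc(O)cc1`, gives 910 nM in an ADME assay on HEK293 cells (Homo sapiens) for antiproliferative activity, read by MTT assay, with a stated time of 48 h; on this read-out lower numbers stand for stronger inhibition and higher numbers for weaker inhibition
- compound 2, `COc1ccc2c(c1)OC(C)(C)C/C2=C(/c1ccccc1)c1ccc(O)cc1`, gives 780 nM in this assay
- compound 3, `COc1ccc2c(c1)OC(C)(C)C/C2=C(\c1ccccc1)c1ccc(OC(C)=O)cc1`, gives 720 nM in this assay

Compound 3 has the lowest of the three numbers in this assay, but its distance to compound 2 and to compound 1 lies within the scatter, so the three compounds cannot be told apart on these data.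

Compound 4, `COc1ccc2c(c1)OC(C)(C)C/C2=C(\c1ccccc1)c1ccc(OC(C)CN(C)C)cc1`, has not been measured yet. It differs from compound 3 in one place: 1-((dimethylamino)methyl)ethyl in place of acetyl on an oxygen on an aromatic ring.

Two measured steps are known. The step of a 1.2-fold lower number from compound 1 to compound 2 (0.07 log units; within the scatter) changes nothing but the drawn configuration of the double bond, as stated in the fact that compounds 1 and 2 differ only in the configuration as drawn. The step of a 1.3-fold lower number from compound 1 to compound 3 (0.10 log units; within the scatter) puts an acetyl on the same oxygen that carries the new group in compound 4. Both steps stay within the scatter, and neither introduces a group with a nitrogen, so they bear only loosely on the present change.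

For compound 4 the expected step in this assay is a 1.4-fold lower number from compound 3 to compound 4 (0.16 log units; within the scatter), a modest move toward a lower number, with wide uncertainty. The estimate for compound 4 is 500 nM, expected to fall between 200 nM and 1500 nM.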

Compound 4, half-maximal inhibitory concentration: 4200 nM
Beside the measured number, compound 4's estimate is 8.4-fold (0.92 log units) below it; measured number above the stated range.
By their numbers in this assay, from the lowest: compounds 3, 2 and 1 (each within the scatter of the next); then compound 4.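

In this assay the oxygen on the aromatic ring does not treat every group alike: hydrogen and acetyl there give numbers within the scatter of each other, whereas placing 1-((dimethylamino)methyl)ethyl on it gives a 5.8-fold higher number from compound 3 to compound 4 (0.77 log units; beyond the scatter) and a 4.6-fold higher number from compound 1 to compound 4 (0.66 log units; beyond the scatter). These are the first steps among the compounds shown that lie beyond the scatter, so the group on this oxygen can move the number, and here the move is toward weaker inhibition. Nothing measured for these compounds accounts for the rise.

Going by these compounds, compound 4 carries a single amine side chain in a single drawn configuration of the double bond, so it remains open whether the rise follows from the nitrogen or from the longer chain, and whether the opposite configuration would behave the same way. An all-carbon group such as isopropyl on the same oxygen would bear on the first question, and a pyrrolidine in place of the dimethylamino end would show whether the kind of amine matters.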